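Swapping a Hydroxyl for Two Methoxy Groups on the Aryl Ring

The compounds below may be only part of what the source reports. "The series", "measured", "known", "first", "only" and "open" are said of these compounds alone.

Of the compounds shown here, two from this series have been tested so far. Compound 1 `O=C(N/N=C/c1ccc(F)cc1)c1cccnc1Nc1cccc(C(F)(F)F)c1` gives 41.3% in a functional assay on the whole organism (strain Wistar) for inhibition, with Rattus norvegicus as the target, read by paw edema, with a stated time of 3 h, at a dose of 10 mg/kg by the intraperitoneal route; on this read-out lower numbers stand for less inhibition and higher numbers for more inhibition at the one dose given (going by the name of the read-out). Compound 2 `O=C(N/N=C/c1ccc(O)cc1)c1cccnc1Nc1cccc(C(F)(F)F)c1`, which differs only by a hydroxy in place of fluoro on an aromatic carbon, gives 59.5% in this assay, a step of a number 18.2 percentage points higher from compound 1 to compound 2 (beyond the scatter). Going by the values given here, on these two numbers compound 2 stands highest, with compound 1 as its only neighbour.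

Compound 3 `COc1ccc(/C=N/NC(=O)c2cccnc2Nc2cccc(C(F)(F)F)c2)c(OC)c1` has not yet been measured. It differs from compound 2 as follows: 2,4-dimethoxyphenyl in place of 4-hydroxyphenyl on a carbon with a double bond to nitrogen. Among the compounds with values here, no measured step covers this change; the one step known, from compound 1 to compound 2, concerns a hydroxy and a fluoro at this same place and was modest in size. The hydroxy that accompanied the higher number in compound 2 is lost in compound 3, so a small decrease or no change beyond the scatter is expected in this assay. For compound 3 the estimated value in this assay is 50%, within a range of 35% to 65%, which means an expected step of a number 9.5 percentage points lower from compound 2 to compound 3 (within the scatter).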

Compound 3, a percentage reported as inhibition, in the whole organism at one dose (the size of the read-out at that dose, not a potency): 24.1%
Compound 3: middle estimate off by 25.9 percentage points, on the high side; the whole stated range lies above it.
By their numbers in this assay, from the lowest: compound 3; then compound 1; then compound 2.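

In this assay, the change from 4-hydroxyphenyl to 2,4-dimethoxyphenyl on the carbon with a double bond to nitrogen produces a large step: a number 35.4 percentage points lower from compound 2 to compound 3 (beyond the scatter). The new group also falls short of the 4-fluorophenyl group, with a number 17.2 percentage points lower from compound 1 to compound 3 (beyond the scatter) and a size printed as modest, so compound 3 now sits under both earlier compounds and the order at this place runs from 2,4-dimethoxyphenyl through 4-fluorophenyl to 4-hydroxyphenyl. Going by these compounds alone, the earlier pair showed only that a change here could go with a higher number, while this result shows that a change at the same place can also go with a much lower one, though no measurement at hand explains why.

Compound 3 removes the hydroxy and brings in two methoxy groups in a single change, so these compounds cannot separate the loss of the hydroxy from the arrival of either methoxy, and a phenyl ring carrying a single methoxy would help to pull these apart. Going by these compounds, how an amine or a carboxylic acid on this ring would read also remains open.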